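The compounds below may be only part of what the source reports. "The series", "measured", "known", "first", "only" and "open" are said of these compounds alone.

In a functional assay on MCF7 cells (Homo sapiens) for inhibition, read by sulforhodamine B assay, with a stated time of 72 h (a lower number here means a stronger inhibitor of growth, a higher number a weaker inhibitor of growth), compound 1 `CNC(=O)/C=C/c1ccncc1-c1ccc2ccccc2c1` gives 9340 nM. Compound 3 `O=C(/C=C/c1ccncc1-c1ccc2ccccc2c1)NC1CC1` gives 6840 nM, and the comparison of the two is a 1.4-fold lower number from compound 1 to compound 3 (0.14 log units; within the scatter), with cyclopropyl in place of methyl on an amide-type nitrogen. Compound 2 `CCOC(=O)/C=C/c1ccncc1-c1ccc2[nH]ccc2c1` gives > 10000 nM, which is a limit of the assay and not a number.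

Compound 4 `O=C(O)/C=C/c1ccncc1-c1ccc2[nH]ccc2c1` departs from compound 2 by hydrogen in place of ethyl on an oxygen next to a carbonyl group, turning ethoxycarbonyl to carboxy. Among the compounds with values here, no measured step makes this change. Within the data shown here, the one measured step, between compound 1 and compound 3, lies on an amide-type nitrogen and gives no direct size for the change here. With only a limit as the starting point, no shift beyond the scatter is expected in this assay, and the expected step is a step that the limit leaves unreadable from compound 2 to compound 4. The estimate for compound 4 is 15000 nM, with an expected range from 6000 nM to 40000 nM.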

Compound 4, concentration for 50% growth inhibition: > 10000 nM
Compound 4: no number, only a limit; the forecaster's own chance of this, stated with the estimate: 80%; the middle value is on the limit's open side.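

In this assay compound 4 gives > 10000 nM as a limit of the assay and not a number. No step can be read between compound 2 and compound 4, because both stand at a limit: the limit of > 10000 nM in this assay, at which 2 of the 4 values shown sit. The compounds shown leave open how far hydrogen in place of ethyl on an oxygen next to a carbonyl group moves growth inhibition.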